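Two More Carbons on a Side Chain of Compound 1

A few compounds are considered here, and "the series" means these few. Any claim that something is new, unique, unknown or untested is made for them only; others in the source may bear on it.

Compound 1 `CCCCCC/C(=N\OCCC)c1cc(OC)c2c(c1OC)C(=O)C=CC2=O` — > 10 ug/mL
Compound 2 `COc1cc(/C=N/OCc2ccccc2)c(OC)c2c1C(=O)C=CC2=O` — > 10 ug/mL
Compound 3 `CCCCCCCCCCCCO/N=C/c1cc(OC)c2c(c1OC)C(=O)C=CC2=O` — > 10 ug/mL

In a functional assay on A549 cells (Homo sapiens) for antiproliferative activity (a higher number here means that more compound is needed for the effect, a lower number that less compound is needed), compound 1 gives > 10 ug/mL, which is a limit of the assay rather than a number. Compound 2 likewise reaches only > 10 ug/mL, again a limit. Compound 3 stops at > 10 ug/mL, once more a limit. All three thus share (the limit of > 10 ug/mL in this assay, at which 3 of the 3 values shown sit). Within the data shown here, no compound yields a number, so no step between measured compounds can be sized. Compound 1 stands level with compound 2 and compound 3 as far as the figures go: nothing separates them, and nothing ranks them.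

Compound 4 `CCCCCC/C(=N\OCCCCC)c1cc(OC)c2c(c1OC)C(=O)C=CC2=O` differs from compound 1 by ethyl in place of hydrogen on a saturated chain carbon, three bonds along the chain from an oxygen. Among the measured compounds shown here, with every value shown sitting at the limit, there is no measured step to lean on, and the data give no hint of direction for this change. The expected step is a step that the limit leaves unreadable from compound 1 to compound 4, that is, none beyond the scatter, and the most likely outcome for compound 4 is that this assay again returns only a limit. Compound 4 is therefore estimated at 15 ug/mL, with a range from 5 ug/mL to 40 ug/mL.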

Compound 4, concentration for half-maximal effect: > 10 ug/mL
Compound 4 gave a limit, no number (the forecaster's own chance of this, stated with the estimate: 70%); the middle value is on the limit's open side.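

In this assay compound 4 gives > 10 ug/mL, which is a limit and not a number. Compound 1 also sits at a limit, so no step can be read between compound 1 and compound 4: the limit of > 10 ug/mL in this assay, at which 4 of the 4 values shown sit.

The compounds shown leave open whether ethyl in place of hydrogen on this chain changes the activity at all, and in which direction.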